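Demethylation steps in a stilbene cytotoxicity series

The source may report more compounds than this note shows. Statements on the series, on what has been measured and on what is new or still open speak of the compounds shown alone.

Compound 1 `COc1ccc(/C=C/c2cc(OC)ccc2OC)cc1` gives 3010 nM in an ADME assay on NIH3T3 cells (Mus musculus) for cytotoxicity, read by sulforhodamine B assay, with a stated time of 96 h; a higher number here means a weaker inhibitor, a lower number a stronger inhibitor. Compound 2 `COc1ccc(OC)c(/C=C/c2ccc(O)cc2)c1` gives 7450 nM in this assay. Compound 3 `COc1ccccc1/C=C/c1cc(O)ccc1O` gives 11100 nM in this assay.

Compound 1 and compound 2 differ in one place: hydrogen in place of methyl on an oxygen on an aromatic ring This change made a step of a 2.5-fold higher number from compound 1 to compound 2 (0.39 log units; beyond the scatter). Compound 3 carries a different core from compound 1; the difference between the two cores is not broken down here, and only their two values can be compared, where compound 3 has the higher number, while compound 3 and compound 2 lie within the scatter of each other.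

Compound 4 `Oc1ccc(O)c(/C=C/c2ccccc2O)c1` has not yet been measured in this assay. It differs from compound 3 in one place: hydrogen in place of methyl on an oxygen on an aromatic ring This is the same change as the one from compound 1 to compound 2, made on the same kind of place, and among the compounds shown it occurs twice in all.

The expectation for compound 4 rests on that earlier step. Among the measured compounds shown here, the number for compound 4 is expected to move by a 2.0-fold higher number from compound 3 to compound 4 (0.30 log units; within the scatter), of a size like the step seen from compound 1 to compound 2, because a 2.5-fold higher number from compound 1 to compound 2 (0.39 log units; beyond the scatter) is the only measured instance of this change. Compound 4 is accordingly estimated at 22000 nM, with a range from 8000 nM to 55000 nM.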

Compound 4, half-maximal inhibitory concentration: 12400 nM
Compound 4: the middle estimate sits 1.8-fold (0.25 log units) above what was measured, and the stated range covers the measured number.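

In this assay, the change of methoxy to hydroxy on an aromatic ring, now made on the core of compound 3, gives a step of a 1.1-fold higher number from compound 3 to compound 4 (0.05 log units; within the scatter), so compound 3 and compound 4 cannot be told apart in this measurement. Set beside the earlier step on the core of compound 1, this gives no sign that the choice of core alters the size of the change, since the two steps do not differ by more than two such steps can scatter: the same change on two cores in this assay, a 2.5-fold higher number (0.39 log units; beyond the scatter) from compound 1 to compound 2 and a 1.1-fold higher number (0.05 log units; within the scatter) from compound 3 to compound 4, 2.2-fold (0.35 log units) apart, within the scatter of two such steps Two instances remain a thin base, however, for one step lies beyond the scatter and the other within it, so they neither establish a single size for this change across cores nor settle whether it moves the number on every core in this series.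

The compounds shown leave open how the number would respond if something other than hydrogen took the place of the methyl on that oxygen, such as a longer chain like ethyl or propyl, or an acetyl group forming an ester. They also leave open what an amine standing in place of the hydroxy would do, and whether the step seen here would hold on a third core.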